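Opening a Ring: Cyclohexyl to Hexyl on the Amide-Type Nitrogen

This account rests on a few compounds, and the source may have more. Where it says the series, first, only, none or still open, it means among the compounds named here.

Compound 1 `Cc1nc(N)sc1CCCN/C(N)=N/C(=O)NC1CCCCC1`: 0.43
Compound 2 `Cc1nc(N)sc1CCCN/C(N)=N/C(=O)NC(C)c1cccc(F)c1`: 0.3
Compound 3 `CCCCCCNC(=O)/N=C(\N)Nc1cccc(-c2csc(N)n2)c1`: "not determined" (no result reported)

Three compounds share a common pattern and were examined in a functional assay on HEK293T cells for agonist activity at histamine H2 receptor (Homo sapiens), read by beta-arrestin recruitment; on this read-out lower numbers stand for smaller maximal responses and higher numbers for larger maximal responses. Compound 1 gives 0.43, the highest of the two numbers at hand. Compound 2 gives 0.3, which lies beyond the scatter below compound 1. For compound 3 no result was reported in this assay, so it contributes no number to the comparison.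

Compound 4 `CCCCCCNC(=O)/N=C(\N)NCCCc1sc(N)nc1C` has not been measured in this assay. Compared with compound 1, the change is hexyl in place of cyclohexyl on an amide-type nitrogen. Within the data shown here, nothing among the measured compounds shows what opening the ring at this position does to the maximal response; the only step with two numbers, from compound 1 to compound 2, changes a different part of the molecule. With no shown step for this kind of change, the expectation for compound 4 rests on compound 1 alone, and the step is expected to be small, with the response of compound 4 most likely staying near that of compound 1, within the scatter or slightly lower. The step from compound 1 to compound 4 is thus estimated at a number 0.030 lower from compound 1 to compound 4 (within the scatter). On this basis, compound 4 is expected to give about 0.4 in this assay, in a range from 0.25 to 0.55.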

Compound 4, intrinsic activity: the largest response reached, as a fraction of the reference agonist's: 0.28
The estimate for compound 4 lay 0.12 above the measured number; measured number inside the range.
By their numbers in this assay, from the lowest: compounds 4 and 2 (each within the scatter of the next); then compound 1.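

In this assay, the exchange of cyclohexyl for hexyl on an amide-type nitrogen comes out a number 0.15 lower from compound 1 to compound 4 (beyond the scatter), the first step at this position and the only one shown for this change. Cyclohexyl and hexyl each count 6 carbon atoms and neither carries a hydrogen-bond donor or acceptor, so this pair separates the presence of the ring from the number of atoms: on this read-out, the closed ring and the open chain are not interchangeable here, at least on the core of compound 1. No measurement given here accounts for the step, which therefore stands as an observation without an explanation.

From the compounds shown here alone, a single pair gives no trend, so it remains open whether a cyclopentyl ring, a butyl chain or a longer chain such as octyl would stay close to compound 1 or to compound 4. Going by these compounds, it is equally open whether a hexyl chain ending in an amine or a carboxylic acid would keep this response, and whether the same ring opening would give a comparable step on a different core.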